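This account rests on a few compounds, and the source may have more. Where it says the series, first, only, none or still open, it means among the compounds named here.

In a functional assay on A549 cells (Homo sapiens) for inhibition, read by sulforhodamine B assay (a higher number here means a weaker inhibitor of growth, a lower number a stronger inhibitor of growth), compound 2 (`Fc1ccc(-c2ccc(-c3ccc(-c4nc5ccccc5[nH]4)cc3)cc2)cc1`) gives 33200 nM and stands at the high end of this small set. Compound 3 (`Oc1ccc(-c2ccc(-c3ccc(-c4nc5ccccc5[nH]4)cc3)cc2)cc1`) gives 33100 nM and sits level with it, while compound 1 (`Cc1ccc2[nH]c(-c3ccc(-c4ccc(-c5cccc(Cl)c5)cc4)cc3)nc2c1`) gives 2800 nM as a lower number, beyond the usual scatter of repeats.

Compound 4 (`Cc1ccc2[nH]c(-c3ccc(-c4ccc(-c5ccc(F)cc5)cc4)cc3)nc2c1`) keeps compound 2 intact apart from one change, methyl in place of hydrogen on an aromatic carbon. Within the data shown here, only one measured step links two compounds directly. That step, a 1.0-fold lower number from compound 2 to compound 3 (0.00 log units; within the scatter), swaps fluoro for hydroxy elsewhere in the molecule and says little about a methyl.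

Among the measured compounds shown here, the nearest evidence is compound 1 at 2800 nM, the only measured compound carrying this methyl. It also differs from compound 2 in a second place, so its lower number cannot be credited to the methyl alone. A modest drop is therefore a reasonable expectation, covering only part of that gap, and no change beyond the scatter remains possible. In this assay the expected result is a 2.8-fold lower number from compound 2 to compound 4 (0.44 log units; beyond the scatter) as a cautious estimate. For compound 4 the estimated value is 12000 nM with an expected range from 3500 nM to 35000 nM in this measurement.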

Compound 4, concentration for 50% growth inhibition: 6030 nM
Compound 4: the middle estimate sits 2.0-fold (0.30 log units) above what was measured, within the range that was stated.
By their numbers in this assay, from the lowest: compound 1; then compound 4; then compounds 3 and 2 (each within the scatter of the next).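

In this assay the methyl now has a step of its own, a 5.5-fold lower number from compound 2 to compound 4 (0.74 log units; beyond the scatter), with nothing else in the molecule changed, so this one added carbon on the fused ring system is enough to move the number beyond the scatter. Among these compounds, until now the only compound carrying this methyl was compound 1, which also has 3-chlorophenyl where compound 2 has 4-fluorophenyl, so the two changes could not be told apart. Among the compounds shown here, the second step, a 2.2-fold higher number from compound 1 to compound 4 (0.33 log units; beyond the scatter), holds the methyl fixed and changes only that end group; it also lies beyond the scatter, so the low number of compound 1 rests on both changes and not on the methyl alone.

Nothing available here explains why either change shifts the growth inhibition. The compounds shown also leave open whether a longer chain such as ethyl, a methoxy group, an amine or a carboxylic acid on the same aromatic carbon would give a step of similar size, and whether the methyl would have the same effect alongside the hydroxy group of compound 3.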